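A few compounds are considered here, and "the series" means these few. Any claim that something is new, unique, unknown or untested is made for them only; others in the source may bear on it.

In an assay on membranes from liver for displacement of a labelled ligand from Sigma intracellular receptor 2 (Rattus norvegicus), read by radiometric assay, with a stated time of 60 min, in the presence of a further agent that is not named here (on this read-out lower numbers stand for stronger inhibition and higher numbers for weaker inhibition), compound 1 `O=C(c1ccc(F)cc1)C1CCN(Cc2ccc(Br)cc2)CC1` gives only a limit, > 854 nM. Compound 2 `OC(c1ccc(F)cc1)C1CCN(Cc2ccc(F)cc2)CC1` likewise reaches only a limit in this assay, > 854 nM. Both values sit at the limit of > 854 nM in this assay, at which 2 of the 2 values shown sit, so the numbers shown do not separate one compound from the other. Compound 3 `Cc1ccc(CN2CCC(C(O)c3ccc(F)cc3)CC2)cc1` differs from compound 2 by methyl in place of fluoro on an aromatic carbon. For the measured compounds named here, no measured step of this kind exists here, and every measured value is a limit, so the expected step, a step that the limit leaves unreadable from compound 2 to compound 3, is nothing beyond the scatter. Compound 3 is therefore estimated at about 1500 nM in this assay, between 400 nM and 6000 nM.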

Compound 3, inhibition constant: > 854 nM
Compound 3 was reported as a limit; the forecaster's own chance of this, stated with the estimate: 60%; the middle value does not contradict the limit.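

Compound 2 and compound 3 are both reported only as limits, so no step can be read between them: the limit of > 854 nM in this assay, at which 3 of the 3 values shown sit.

The compounds shown leave open whether 4-fluorophenyl or 4-methylphenyl makes any difference in this assay.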